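Swapping an Allyl Chain for Hydroxymethyl

The source may report more compounds than this note shows. Statements on the series, on what has been measured and on what is new or still open speak of the compounds shown alone.

In a functional assay on HOS cells (Homo sapiens) for antiproliferative activity, read by sulforhodamine B assay (on this read-out lower numbers stand for stronger inhibition of growth and higher numbers for weaker inhibition of growth), compound 1 (`CC[C@@H]1O[C@H](COCc2ccccc2)[C@@H](OCc2ccccc2)[C@H](OCc2ccccc2)[C@H]1O`) gives 34200 nM, compound 2 (`CCC[C@@H]1O[C@H](COCc2ccccc2)[C@@H](OCc2ccccc2)[C@H](OCc2ccccc2)[C@H]1O`) gives 38600 nM and compound 3 (`C=CC[C@@H]1O[C@H](COCc2ccccc2)[C@@H](OCc2ccccc2)[C@H](OCc2ccccc2)[C@H]1O`) gives 44100 nM. Compound 3 therefore stands level with the other two, as its steps to them show: a 1.3-fold higher number from compound 1 to compound 3 (0.11 log units; within the scatter) and a 1.1-fold higher number from compound 2 to compound 3 (0.06 log units; within the scatter).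

Compound 4 (`OC[C@@H]1O[C@H](COCc2ccccc2)[C@@H](OCc2ccccc2)[C@H](OCc2ccccc2)[C@H]1O`) differs from compound 3 in one place: hydroxy in place of vinyl on a saturated chain carbon bound to a saturated ring carbon. In words, this is hydroxy in place of vinyl on a saturated chain carbon bound to a saturated ring carbon, which also reads as allyl to hydroxymethyl.

For the measured compounds named here, the steps that bear on this change are those among the other chains: the two above and a 1.1-fold higher number from compound 1 to compound 2 (0.05 log units; within the scatter). All are small, but none of them brings in a hydroxy group, so they are only a loose guide and the range must stay wide. The estimated size of the change is a 1.1-fold lower number from compound 3 to compound 4 (0.04 log units; within the scatter), so no shift beyond the scatter is expected in this assay. For compound 4 the estimated value is 40000 nM, with an expected range from 15000 nM to 100000 nM.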

Compound 4, concentration for 50% growth inhibition: 27300 nM
Beside the measured number, compound 4's estimate is 1.5-fold (0.17 log units) above it; measured number inside the range.
By their numbers in this assay, from the lowest: compounds 4, 1, 2 and 3 (each within the scatter of the next).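

In this assay, hydroxy in place of vinyl, ethyl or methyl on this saturated chain carbon bound to a saturated ring carbon leaves the number within the scatter each time (a 1.6-fold lower number from compound 3 to compound 4 (0.21 log units; within the scatter); a 1.4-fold lower number from compound 2 to compound 4 (0.15 log units; within the scatter); a 1.3-fold lower number from compound 1 to compound 4 (0.10 log units; within the scatter)). The earlier chains held carbon only, so the new information is that a chain carrying oxygen, with a hydrogen-bond donor and acceptor that vinyl lacks, also stands level with them at this position. Nothing available explains why the number holds steady across these chains.

As far as these compounds go, whether an amine or a carboxylic acid at this position would stay level remains open, as does the effect of a much longer chain. No compound shown here moves the number beyond the scatter, so what this position can contribute to growth inhibition is still unknown.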